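The source may hold more compounds than are shown below. What is called first, only, known or untested is meant among the compounds shown, and "the series" means these compounds.

In a functional assay on SK-OV-3 cells (Homo sapiens) for inhibition, read by CCK-8 assay, with a stated time of 70 h (a lower number here means a stronger inhibitor, a higher number a weaker inhibitor), compound 1 `c1ccc(COc2ccc(OCCOCCOC3CCCC3)cc2)cc1` gives > 100000 nM, which is a limit of the assay and not a number. Compound 4 `c1ccc(COc2ccc(OCCOCCNC3CC3)cc2)cc1` keeps the core of compound 1 and changes one end of the chain: cyclopropylamino in place of cyclopentyloxy on a saturated chain carbon, two bonds along the chain from an oxygen on a saturated carbon. Two relatives give real numbers. Compound 2 `Nc1ccc(COc2ccc(OCCOCCNC3CCCC3)cc2)cc1` gives 31700 nM, and compound 3 `c1ccc(COc2ccc(COc3ccc(OCCOCCNC4CCCC4)cc3)cc2)cc1` gives 10000 nM. Going by the values given here, both have a nitrogen where compound 1 has the oxygen of its cyclopentyloxy group, but both keep a five-membered ring, and no measured compound carries the three-membered ring of compound 4. Among the compounds with values here, the only measured step, a 3.2-fold lower number from compound 2 to compound 3 (0.50 log units; beyond the scatter), is modest and comes from benzyloxy in place of amino on an aromatic carbon, a different place from this change. It therefore offers only a rough guide to scale. The expected change is an at least 3.3-fold lower number from compound 1 to compound 4 (0.52 log units; beyond the scatter), towards a lower number, and its size is uncertain. For compound 4, the estimated value is 30000 nM, with an expected range from 10000 nM to 90000 nM.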

Compound 4, half-maximal inhibitory concentration: 47200 nM
Beside the measured number, compound 4's estimate is 1.6-fold (0.20 log units) below it, within the range that was stated.
By their numbers in this assay, from the lowest: compound 3; then compounds 2 and 4 (each within the scatter of the next). At a limit, above all of these: compound 1.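

In this assay, cyclopropylamino in place of cyclopentyloxy on this saturated chain carbon gives an at least 2.1-fold lower number from compound 1 to compound 4 (0.32 log units; beyond the scatter), so this change to the core of compound 1 alone is enough to bring a measurable value. The step combines two changes, a nitrogen for the oxygen and a three-membered ring for a five-membered one, and it cannot show which of them matters. Compound 1 stands at a limit and not at a number, so the step gives only a bound on the true size of the change: the limit of > 100000 nM in this assay, at which 1 of the 4 values shown sits.

A cyclopentylamino group on the core of compound 1 would separate the effect of the nitrogen from that of the ring size. As far as these compounds go, how a cyclohexylamino group, an open-chain dimethylamino group or a longer chain would read at this place remains open.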